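From 2-cyanophenyl to 4-(pyrrolidin-1-yl)phenyl on the imine carbon

This account rests on a few compounds, and the source may have more. Where it says the series, first, only, none or still open, it means among the compounds named here.

In an assay on CHO-K1 cells for displacement of a labelled ligand from adenosine receptor A1 (Homo sapiens), read by scintillation counting, with a stated time of 60 min (on this read-out higher numbers stand for weaker inhibition and lower numbers for stronger inhibition), compound 3 `N#Cc1ccccc1/C=N/Nc1nc(N)c2ncn([C@@H]3O[C@H](CO)[C@@H](O)[C@H]3O)c2n1` gives 2.9 nM, the lowest of the two numbers shown. Compound 2 `Nc1nc(N/N=C/c2cncs2)nc2c1ncn2[C@@H]1O[C@H](CO)[C@@H](O)[C@H]1O` gives 22 nM in this assay. Compound 1 `CC(=O)Nc1ccc(/C=N/Nc2nc(N)c3ncn([C@@H]4O[C@H](CO)[C@@H](O)[C@H]4O)c3n2)cc1` reaches only the assay limit of > 10000 nM (the limit of > 10000 nM in this assay, at which 1 of the 3 values shown sits). Compound 4 `Nc1nc(N/N=C/c2ccc(N3CCCC3)cc2)nc2c1ncn2[C@@H]1O[C@H](CO)[C@@H](O)[C@H]1O` differs from compound 3 by 4-(pyrrolidin-1-yl)phenyl in place of 2-cyanophenyl on a carbon with a double bond to nitrogen. Going by the values given here, the steps that bear on this change are an at least 3400-fold lower number from compound 1 to compound 3 (3.53 log units; beyond the scatter), where a 4-acetamidophenyl gave only a limit, and the smaller 7.6-fold lower number from compound 2 to compound 3 (0.88 log units; beyond the scatter). Because an at least 3400-fold lower number from compound 1 to compound 3 (3.53 log units; beyond the scatter) was large, returning to a phenyl carrying a group in the 4-position, as in compound 1, is expected to raise the number, though by an uncertain amount. Compound 4 is therefore expected to give 300 nM, between 30 nM and 5000 nM. This estimate means an expected step of a 100-fold higher number from compound 3 to compound 4 (2.01 log units; beyond the scatter).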

Compound 4, inhibition constant: 5.1 nM
Beside the measured number, compound 4's estimate is 59-fold (1.77 log units) above it; the whole stated range lies above it.
By their numbers in this assay, from the lowest: compounds 3 and 4 (each within the scatter of the next); then compound 2. At a limit, above all of these: compound 1.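

In this assay, a 4-(pyrrolidin-1-yl)phenyl group on the imine carbon keeps the number low: a 1.8-fold higher number from compound 3 to compound 4 (0.25 log units; within the scatter), and a 4.3-fold lower number from compound 2 to compound 4 (0.63 log units; beyond the scatter). Exchanging only the group on the phenyl ring gives an at least 1900-fold lower number from compound 1 to compound 4 (3.29 log units; beyond the scatter), so the loss in compound 1 goes with acetamido and not with the phenyl ring as such. Compound 1 itself stands at a limit, not a number: the limit of > 10000 nM in this assay, at which 1 of the 4 values shown sits.

Going by these compounds, it remains open whether a dimethylamino group, a morpholine or a carboxylic acid in place of pyrrolidin-1-yl would stay close to compound 4 or fall towards compound 1.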